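The source may report more compounds than this note shows. Statements on the series, on what has been measured and on what is new or still open speak of the compounds shown alone.

Within the data shown here, in a functional assay on A-375 cells (Homo sapiens) for activation, with a stated time of 3 days (on this read-out higher numbers stand for an effect only at larger amounts of compound and lower numbers for an effect already at smaller amounts), three compounds have numbers so far. Compound 1 `O=C(Nc1ccc(-c2cscn2)cc1)[C@H]1CCCN(Cc2ccc(F)c(F)c2)C1` gives 270 nM, compound 2 `O=C(Nc1ccc(-c2ccc[nH]2)cc1)C1CCCN(Cc2ccc(F)c(F)c2)C1` gives 720 nM, and compound 3 `O=C(Nc1ccc(-c2ccc[nH]2)cc1)[C@@H]1CCCN(Cc2ccc(F)c(F)c2)C1` gives 19900 nM. That last number is the highest of the three, so compound 3 needs the largest amount to show its effect.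

The move to compound 4 `O=C(Nc1ccc(-c2ccc[nH]2)cc1)[C@H]1CCCN(Cc2ccc(F)c(F)c2)C1` alters a single feature: the two compounds have the same atoms and bonds and differ only in configuration as drawn: 1 of 1 stereo elements differ; a stereocentre at a saturated ring carbon is drawn R in compound 3 and S in compound 4. Mirror-image forms like these can behave very differently in cells.

Among the measured compounds shown here, one measured step bears on this change: a 28-fold higher number from compound 2 to compound 3 (1.44 log units; beyond the scatter), which is large and beyond the scatter. The only structural difference behind that step is the fact that one of compounds 2 and 3 is drawn with a defined configuration and the other without, at the place where they differ. Suppose compound 2, at 720 nM, is a mixture of the R and S forms. Its effect would then have to come mostly from the S form, since the R form, compound 3, reaches only 19900 nM. The S form, compound 4, should then need somewhat less than the mixture does. A large fall in the number is therefore expected, with an estimated 57-fold lower number from compound 3 to compound 4 (1.75 log units; beyond the scatter), well beyond the scatter. For compound 4 the expected value is 350 nM, with an estimated range of 150 nM to 800 nM.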

Compound 4, half-maximal effective concentration: 140 nM
Estimate against measurement, compound 4: 2.5-fold (0.40 log units) above; the measured number lies below the stated range.
By their numbers in this assay, from the lowest: compounds 4 and 1 (each within the scatter of the next); then compound 2; then compound 3.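

In this assay, the configuration at this saturated ring carbon has a very large effect, with a 140-fold lower number from compound 3 to compound 4 (2.15 log units; beyond the scatter), and the change in number can be tied to that carbon alone: the fact that compounds 3 and 4 differ only in the configuration as drawn

The defined S form also improves on the form drawn without a configuration, with a 5.1-fold lower number from compound 2 to compound 4 (0.71 log units; beyond the scatter), which shows that the undefined drawing understates what the S form can do: the fact that one of compounds 2 and 4 is drawn with a defined configuration and the other without, at the place where they differ

With the configuration drawn the same way, 1H-pyrrol-2-yl in place of 1,3-thiazol-4-yl gives a 1.9-fold lower number from compound 1 to compound 4 (0.29 log units; within the scatter), so these two groups cannot be ranked in this assay, and the thiazole-bearing compound 1 and the pyrrole-bearing compound 4 stand level within the usual scatter.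

Whether the configuration at this carbon matters as much when 1,3-thiazol-4-yl is present remains open, as the compounds shown pair the opposite form only with 1H-pyrrol-2-yl. Going by these compounds, it is also open how the S form would respond if a carboxylic acid or an amine stood in place of these two groups.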